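The compounds below may be only part of what the source reports. "The series", "measured", "known", "first", "only" and "open" are said of these compounds alone.

Three compounds share one core and differ only in the group attached to the nitrogen on the aromatic ring. Compound 1 `O=C(Nc1cccc(/C=C/C(=O)c2nc3ccccc3[nH]2)c1)c1cccc(Br)c1` carries a (3-bromophenyl)carbonyl there, and in a functional assay on HCT-116 cells (Homo sapiens) for antiproliferative activity, read by MTT assay, with a stated time of 48 h (a higher number here means a weaker inhibitor, a lower number a stronger inhibitor), compound 1 gives 1560 nM. Compound 2 `O=C(/C=C/c1cccc(NS(=O)(=O)c2ccccc2Cl)c1)c1nc2ccccc2[nH]1` carries a (2-chlorophenyl)sulfonyl instead, and in this assay compound 2 gives 987 nM; the step is a 1.6-fold lower number from compound 1 to compound 2 (0.20 log units; within the scatter). Compound 3 `O=C(/C=C/c1cccc(NS(=O)(=O)c2ccc(Cl)cc2)c1)c1nc2ccccc2[nH]1` carries a (4-chlorophenyl)sulfonyl, and in this assay compound 3 gives 1960 nM. On the bare numbers compound 3 stands at the top of the three, yet its steps from the others, a 1.3-fold higher number from compound 1 to compound 3 (0.10 log units; within the scatter) and a 2.0-fold higher number from compound 2 to compound 3 (0.30 log units; within the scatter), both stay within the scatter, so no real order among the three can be claimed.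

Compound 4 `Cc1cccc(S(=O)(=O)Nc2cccc(/C=C/C(=O)c3nc4ccccc4[nH]3)c2)c1` has not yet been measured. It differs from compound 3 at one point: 3-methylphenyl in place of 4-chlorophenyl on a sulfonyl sulfur. Among the measured compounds shown here, the one measured step at the same place, a 2.0-fold higher number from compound 2 to compound 3 (0.30 log units; within the scatter), stayed within the scatter, and the two sulfonyl analogues sit close to the carbonyl compound as well. A move beyond the scatter is therefore not expected in this assay; the expected step is a 1.3-fold lower number from compound 3 to compound 4 (0.12 log units; within the scatter). The estimated value for compound 4 in this assay is 1500 nM, with a range from 600 nM to 4000 nM.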

Compound 4, half-maximal inhibitory concentration: 597 nM
Compound 4: middle estimate off by 2.5-fold (0.40 log units), on the high side, outside the stated range (below it).
By their numbers in this assay, from the lowest: compounds 4, 2, 1 and 3 (each within the scatter of the next, the first and the last beyond it).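

Among the compounds shown here, the choice of group on the sulfonyl sulfur can matter in this assay: moving from 4-chlorophenyl to 3-methylphenyl gives a 3.3-fold lower number from compound 3 to compound 4 (0.52 log units; beyond the scatter) and is the first step at this position to clear the scatter, though the step is only modest. The picture stays limited, since replacing 2-chlorophenyl with the same 3-methylphenyl gives a 1.7-fold lower number from compound 2 to compound 4 (0.22 log units; within the scatter) and those two compounds cannot be placed in order. For the compounds shown here, putting (3-methylphenyl)sulfonyl in place of (3-bromophenyl)carbonyl on the nitrogen gives a 2.6-fold lower number from compound 1 to compound 4 (0.42 log units; beyond the scatter) and is the first such swap to clear the scatter, but it changes both the carbonyl-to-sulfonyl link and the ring at once, so the step cannot be assigned to either part alone.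

The compounds shown do not settle whether the step from compound 3 follows the methyl group, the chlorine leaving, or the new ring position, a question that 3-chlorophenyl and 4-methylphenyl on the sulfonyl sulfur would help separate. Nothing presented here explains why this step occurs.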